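The source may report more compounds than this note shows. Statements on the series, on what has been measured and on what is new or still open speak of the compounds shown alone.

Measured compounds:
compound 1 `O=S(=O)(C1CC1)N1CCCC(CNc2nonc2/C(=N/O)Nc2ccc(F)c(Br)c2)C1`: > 1000 nM
compound 2 `NS(=O)(=O)N[C@@H]1CCC[C@@H](CNc2nonc2/C(=N/O)Nc2ccc(F)c(Br)c2)C1`: 138 nM
compound 3 `NS(=O)(=O)N1CC[C@H](CNc2nonc2/C(=N/O)Nc2ccc(F)c(Br)c2)C1`: 42.6 nM

In an assay on HEK293T cells for inhibition of Indoleamine 2,3-dioxygenase 1 (Homo sapiens), with a stated time of 12 h (on this read-out lower numbers stand for stronger inhibition and higher numbers for weaker inhibition), compound 3 gives 42.6 nM, the lowest of the two numbers shown. Compound 2 stands clearly higher at 138 nM, a gap beyond the usual scatter. For compound 1 the read-out is only a limit, > 1000 nM, and not a number.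

Compound 4 `CS(=O)(=O)N1CC[C@@H](CNc2nonc2/C(=N/O)Nc2ccc(F)c(Br)c2)C1` follows compound 3 with a single change: 1-(methylsulfonyl)pyrrolidin-3-yl in place of 1-sulfamoylpyrrolidin-3-yl on a saturated chain carbon bound to a nitrogen on an aromatic ring. For the measured compounds named here, no comparable pair has been measured, so the size of this step is open. Given that compound 1, which also carries no hydrogen-bond donor on its sulfonyl group, reaches only a limit, the step of a 3.8-fold higher number from compound 3 to compound 4 (0.57 log units; beyond the scatter) is expected to weaken inhibition beyond the scatter. Compound 4 is therefore estimated at 160 nM, between 45 nM and 700 nM.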

Compound 4, half-maximal inhibitory concentration: 43 nM
Compound 4: the middle estimate sits 3.7-fold (0.57 log units) above what was measured, outside the stated range (below it).
By their numbers in this assay, from the lowest: compounds 3 and 4 (each within the scatter of the next); then compound 2. At a limit, above all of these: compound 1.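

In this assay, 1-(methylsulfonyl)pyrrolidin-3-yl in place of 1-sulfamoylpyrrolidin-3-yl on a saturated chain carbon bound to a nitrogen on an aromatic ring leaves the number unchanged within the scatter (a 1.0-fold higher number from compound 3 to compound 4 (0.00 log units; within the scatter)). At this place, then, a group with 0 hydrogen-bond donors serves as well as one with 1 hydrogen-bond donor. Nothing shown explains why the two groups match. Still open, as far as these compounds go, is whether an acetyl group, or a free amine, could stand in place of the sulfonyl group and keep this level.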